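Acetyl in place of 4-fluorophenyl: compound 3

The source may hold more compounds than are shown below. What is called first, only, known or untested is meant among the compounds shown, and "the series" means these compounds.

Compound 2 `N#Cc1ccc(Nc2nc(Oc3ccnc4ccccc34)nc(N3CCN(c4ccc(F)cc4)CC3)n2)cc1C(F)(F)F` in a functional assay on DU-145 cells (Homo sapiens) for cytotoxicity, read by sulforhodamine B assay, with a stated time of 48 h (on this read-out lower numbers stand for stronger inhibition of growth and higher numbers for weaker inhibition of growth), returns only a limit, > 100000 nM. The same holds for compound 1 `N#Cc1ccc(Nc2nc(Oc3ccnc4ccccc34)nc(N3CCN(c4ccccc4Cl)CC3)n2)cc1C(F)(F)F`, whose result in this assay is likewise the limit > 100000 nM. Going by the values given here, the step that the two limits leave unreadable from compound 1 to compound 2 thus cannot be sized; the only evidence on it is the limit of > 100000 nM in this assay, at which 2 of the 2 values shown sit. Compound 3 `CC(=O)N1CCN(c2nc(Nc3ccc(C#N)c(C(F)(F)F)c3)nc(Oc3ccnc4ccccc34)n2)CC1` differs from compound 2 by acetyl in place of 4-fluorophenyl on an amine nitrogen in a ring. Among the compounds with values here, no measured step bears on this change: the single measured pair consists of two limits, so neither direction nor size is readable from it. Compound 3 is therefore expected to stand where compound 2 does, and the step of a number no higher from compound 2 to compound 3 (the limit leaves the size open) is expected to be none beyond the scatter. The estimate for compound 3 in this assay is 100000 nM, within 30000 nM to 300000 nM, most likely reported once more only as a limit.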

Compound 3, concentration for total growth inhibition: > 100000 nM
Compound 3 gave a limit, no number; the forecaster's own chance of this, stated with the estimate: 80%; the middle value sits exactly at the limit.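

No step among compound 1, compound 2 and compound 3 can be read, as each returns only a limit: the limit of > 100000 nM in this assay, at which 3 of the 3 values shown sit.

The compounds shown leave open whether 2-chlorophenyl, 4-fluorophenyl and acetyl on the amine nitrogen in a ring differ at all, and whether any change to the shared core gives a readable number.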